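The compounds below may be only part of what the source reports. "The series", "measured", "known", "first", "only" and "open" are said of these compounds alone.

Measured in an in vitro ADME assay on microsomes from liver (Homo sapiens) for pharmacokinetics, read by LC-MS, with a stated time of 10 min, tested at 1 uM; a lower number here means slower removal, a higher number faster removal of the compound:
- compound 1 `CN1C[C@H](C(=O)Nc2ccc(C(F)(F)F)cc2)[C@@H](c2ccc(/C=C/C(=O)Nc3ccccc3N)cc2)C1`: 6 mL/min/kg
- compound 2 `CN1C[C@H](C(=O)Nc2cccc(Cl)c2)[C@@H](c2ccc(/C=C/C(=O)Nc3ccccc3N)cc2)C1`: 7 mL/min/kg
- compound 3 `CN1C[C@H](C(=O)Nc2cccnc2)[C@@H](c2ccc(/C=C/C(=O)Nc3ccccc3N)cc2)C1`: 10 mL/min/kg

Compound 3 stands within the scatter of both other compounds: a 1.4-fold higher number from compound 2 to compound 3 (0.15 log units; within the scatter), and a 1.7-fold higher number from compound 1 to compound 3 (0.22 log units; within the scatter). The step under consideration leads to compound 4 `CN1C[C@H](C(=O)NC2CC2)[C@@H](c2ccc(/C=C/C(=O)Nc3ccccc3N)cc2)C1`, with cyclopropyl in place of pyridin-3-yl on an amide-type nitrogen.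

All three measured steps changed the group at this same place, and the remaining one, a 1.2-fold higher number from compound 1 to compound 2 (0.07 log units; within the scatter), also stayed within the scatter. These steps only exchange 4-(trifluoromethyl)phenyl, 3-chlorophenyl and pyridin-3-yl. Among the measured compounds shown here, no measured compound carries a non-aromatic ring here, so their bearing on cyclopropyl is uncertain and the range is kept wide.

In this assay, no change beyond the scatter is therefore expected, with no firm direction. The expected step is a 1.1-fold lower number from compound 3 to compound 4 (0.05 log units; within the scatter). For compound 4 the estimate is 9 mL/min/kg, with an expected range of 4 mL/min/kg to 20 mL/min/kg.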

Compound 4, clearance: 10 mL/min/kg
For compound 4 the middle estimate is 1.1-fold (0.05 log units) below the measured one; low and high end bracket the measured number.
By their numbers in this assay, from the lowest: compounds 1, 2, 3 and 4 (each within the scatter of the next).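

In this assay, the position on the amide-type nitrogen now includes a three-membered non-aromatic ring of carbon only, and replacing the six-membered aromatic ring of pyridin-3-yl with cyclopropyl gives no change at the digits printed from compound 3 to compound 4 (within the scatter). The comparisons with the other aromatic groups stay within the scatter as well, with a 1.4-fold higher number from compound 2 to compound 4 (0.15 log units; within the scatter) and a 1.7-fold higher number from compound 1 to compound 4 (0.22 log units; within the scatter). Across the four groups shown, an aromatic ring at this position is therefore not required for a number within the scatter of the others, and no measurement shown accounts for this.

Still open, going by these compounds, is whether an amine, a carboxylic acid or a longer alkyl chain on this nitrogen would stay within the scatter in this assay. On these data alone, all four compounds share the core of compound 1, so whether this holds on a different core also remains open.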